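The source may report more compounds than this note shows. Statements on the series, on what has been measured and on what is new or still open speak of the compounds shown alone.

Working notes on the series. In a functional assay on BMEC cells (Bos taurus) for antiproliferative activity (a lower number here means a stronger inhibitor, a higher number a weaker inhibitor), compound 1 `COc1cc(/C=C/Cc2cc(O)c3sccc3c2)cc(OC)c1OC` gives 24800 nM and compound 2 `COc1cc(/C=C\Cc2cc(OC)c3c(cnn3C)c2)cc(OC)c1OC` gives 20000 nM. These two values lie within the scatter of each other, so compound 2 cannot be ranked against compound 1, and both sit in the same weak range.

The next compound to be read is compound 3 `COc1cc(/C=C/Cc2cc(OC)c3c(cnn3C)c2)cc(OC)c1OC`. Its relation to compound 2 is simple: the two compounds have the same atoms and bonds and differ only in configuration as drawn: 1 of 1 stereo elements differ; a double bond is drawn Z in compound 2 and E in compound 3. No atom leaves or enters, and only the drawn configuration of the double bond changes.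

For the measured compounds named here, no measured pair isolates this kind of change, so there is no direct precedent for its size in this assay. Going by the values given here, the only nearby reference is compound 1 at 24800 nM, which has a different core and so gives a range rather than a step. A small move towards a higher number is expected, possibly none beyond the scatter. The estimated change is a 1.4-fold higher number from compound 2 to compound 3 (0.15 log units; within the scatter), and the uncertainty is wide. For compound 3 the expected value is 28000 nM, with an estimated range of 10000 nM to 70000 nM.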

Compound 3, half-maximal inhibitory concentration: 32000 nM
Compound 3: the middle estimate sits 1.1-fold (0.06 log units) below what was measured; low and high end bracket the measured number.
By their numbers in this assay, from the lowest: compounds 2, 1 and 3 (each within the scatter of the next).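

In this assay the configuration of the double bond now has a direct measure on the shared core, and the reading is a 1.6-fold higher number from compound 2 to compound 3 (0.20 log units; within the scatter), so compound 2 and compound 3 cannot be ranked against each other. The step can be assigned to the double bond alone, because a single feature separates the pair: the fact that compounds 2 and 3 differ only in the configuration as drawn. With compound 2 at 20000 nM and compound 3 at 32000 nM, neither the Z nor the E form on this core leaves the weak range of the series, and in this pair the drawn configuration gives no measurable handle on the antiproliferative read-out.

The compounds shown leave open whether the same insensitivity holds on the core of compound 1, for which only the E form appears here, so this single pair supports no general statement about double-bond configuration across cores. They also leave open whether the number would respond to a change of another kind on the shared core, such as a saturated or longer chain in place of the double bond, or an amine or a carboxylic acid in place of a methoxy group.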